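Swapping chloro for bromo on a spiro-fused core

A few compounds are considered here, and "the series" means these few. Any claim that something is new, unique, unknown or untested is made for them only; others in the source may bear on it.

Measured compounds:
- compound 1 `N#CC1=C(N)Oc2cc3oc(-c4ccccc4)cc(=O)c3c(O)c2C12C(=O)N(Cc1ccccc1)c1ccc(Cl)cc12` — 36300 nM
- compound 2 `N#CC1=C(N)Oc2cc3oc(-c4ccccc4)cc(=O)c3c(O)c2C12C(=O)N(Cc1ccccc1)c1ccc(Br)cc12` — 36400 nM
- compound 3 `CCN1C(=O)C2(C(C#N)=C(N)Oc3cc4oc(-c5ccc(OC)cc5OC)cc(=O)c4c(O)c32)c2cc(Cl)ccc21` — 8450 nM

The three measured compounds were tested in a functional assay on K562 cells (Homo sapiens) for antiproliferative activity, read by MTT assay, with a stated time of 48 h; on this read-out higher numbers stand for weaker inhibition and lower numbers for stronger inhibition. In this assay compound 1 gives 36300 nM, and compound 2 gives 36400 nM. The two differ in a single place: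

bromo in place of chloro on an aromatic carbon

The resulting step, a 1.0-fold higher number from compound 1 to compound 2 (0.00 log units; within the scatter), shows that the two values sit together, with no order between them.

Compound 3 gives 8450 nM in this assay. How its core differs from that of compound 1 is not broken down here; the two are built differently in more than one place. Compound 3 stands lowest of the three measured numbers, and the gap to compound 1 and to compound 2 lies beyond the scatter.

Compound 4 `CCN1C(=O)C2(C(C#N)=C(N)Oc3cc4oc(-c5ccc(OC)cc5OC)cc(=O)c4c(O)c32)c2cc(Br)ccc21` has not yet been measured. It differs from compound 3 as follows:

bromo in place of chloro on an aromatic carbon

This is the same change that turns compound 1 into compound 2, at a place described in the same words. Because the step of a 1.0-fold higher number from compound 1 to compound 2 (0.00 log units; within the scatter) was flat, compound 4 is expected to sit close to compound 3, with an estimated step of a 1.0-fold higher number from compound 3 to compound 4 (0.00 log units; within the scatter). The estimate for compound 4 in this assay is 8500 nM, expected to fall between 4000 nM and 18000 nM.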

Compound 4, half-maximal inhibitory concentration: 16100 nM
Compound 4: the middle estimate sits 1.9-fold (0.28 log units) below what was measured, and the stated range covers the measured number.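

In this assay, bromo in place of chloro on the core of compound 3 gives a 1.9-fold higher number from compound 3 to compound 4 (0.28 log units; within the scatter), so this step, like the earlier one, cannot be told apart from the ordinary spread of repeated measurements. Set side by side, the two steps show that the change reads the same on both cores, as far as this assay can tell: the same change on two cores in this assay, a 1.0-fold higher number (0.00 log units; within the scatter) from compound 1 to compound 2 and a 1.9-fold higher number (0.28 log units; within the scatter) from compound 3 to compound 4, 1.9-fold (0.28 log units) apart, within the scatter of two such steps This shows only that on these two cores, which are built differently in more than one place, chloro and bromo could not be separated; it does not show that the swap would stay flat on another core, in another assay, or at another place on the ring.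

The compounds shown carry only chloro or bromo at this place, so it stays open what a smaller halogen such as fluoro, or a group of another kind such as an amine or a carboxylic acid, would do there. For the compounds shown here, no pair here changes only the benzyl or ethyl group, or only the aromatic ring with or without its methoxy groups, so what each of these does on its own also stays open.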